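Cyclic amine in place of benzylamino on the pyridine core

A few compounds are considered here, and "the series" means these few. Any claim that something is new, unique, unknown or untested is made for them only; others in the source may bear on it.

Measured so far:
compound 1, `CC(C(=O)NCc1ccc(C(F)(F)F)nc1NCC1CCN(C(=O)OC(C)(C)C)CC1)c1ccc(NS(C)(=O)=O)c(F)c1`: 1140 nM
compound 2, `CC(C(=O)NCc1ccc(C(F)(F)F)nc1NCc1ccccc1)c1ccc(NS(C)(=O)=O)c(F)c1`: 203 nM
compound 3, `C[C@H](C(=O)NCc1ccc(C(F)(F)F)nc1N1CCC[C@H]1CO)c1ccc(NS(C)(=O)=O)c(F)c1`: "not active" (no number reported)

In a functional assay on CHO-K1 cells for antagonist activity at transient receptor potential cation channel subfamily V member 1 (Homo sapiens), read by FLIPR (on this read-out lower numbers stand for stronger inhibition and higher numbers for weaker inhibition), compound 2 gives 203 nM, the lowest of the two numbers reported. Compound 1 gives 1140 nM in this assay, a higher number that lies beyond the scatter. Among the measured compounds shown here, compound 3 was reported as not active in this assay, without a number, and it is the one compound in which the ring nitrogen carries no hydrogen-bond donor.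

Compound 4, `CC(C(=O)NCc1ccc(C(F)(F)F)nc1N1CC=CCC1)c1ccc(NS(C)(=O)=O)c(F)c1`, has not yet been measured. It differs from compound 2 as follows: a group of 6 heavy atoms (5 carbon, 1 nitrogen; one six-membered non-aromatic ring with 1 hetero atom) in place of a group of 8 heavy atoms (7 carbon, 1 nitrogen; one six-membered aromatic ring of carbon only), on an aromatic carbon

Compound 3 shows that a ring closed on the nitrogen with no donor can remove the activity seen in compound 2; compound 1 shows that a saturated ring in the side chain is tolerated at a weaker level. Compound 4 is therefore expected to give a higher number than compound 2, with a real chance of a limit only. The step of a 4.4-fold higher number from compound 2 to compound 4 (0.65 log units; beyond the scatter) is expected to lie beyond the scatter. Compound 4 is estimated at 900 nM, within 200 nM to 5000 nM.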

Compound 4, half-maximal inhibitory concentration: 12.1 nM
Compound 4: the middle estimate sits 74-fold (1.87 log units) above what was measured; the whole stated range lies above it.
By their numbers in this assay, from the lowest: compound 4; then compound 2; then compound 1.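

In this assay, replacing benzylamino with the six-membered non-aromatic ring gives a 17-fold lower number from compound 2 to compound 4 (1.22 log units; beyond the scatter), so at this position, next to the ring nitrogen, neither the aromatic ring of carbon only nor the hydrogen-bond donor of benzylamino is needed for strong inhibition. Compound 3 is also attached through a ring nitrogen and was reported as not active, so attachment through a ring nitrogen does not by itself decide the outcome. Nothing at hand gives a reason for the size of this step.

On these data alone, whether the double bond of compound 4 contributes remains open, and a piperidine attached directly through its nitrogen would address that. A morpholine at the same position would show whether a further ring hetero atom is accepted there.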